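Swapping the para substituent on the urea aryl ring

This account rests on a few compounds, and the source may have more. Where it says the series, first, only, none or still open, it means among the compounds named here.

Compound 1 `CCOc1ccc(NC(=O)Nc2cccc(CNc3nccnc3Cl)c2)cc1` is the compound to start from. In a functional assay on HepG2 cells (Homo sapiens) for antiproliferative activity, read by MTT assay, with a stated time of 48 h (on this read-out lower numbers stand for stronger inhibition and higher numbers for weaker inhibition), compound 1 gives 7050 nM, the lowest of the two numbers shown. Compound 2 `O=C(Nc1cccc(CNc2nccnc2Cl)c1)Nc1ccccc1F` gives 10500 nM in this assay, and the step of a 1.5-fold higher number from compound 1 to compound 2 (0.17 log units; within the scatter) stays within the scatter. Compound 3 `O=C(Nc1cccc(CNc2nccnc2Cl)c1)NC1CCCCC1`, with a cyclohexyl in place of the aryl group, reaches only the limit of this assay, > 40000 nM. The steps of an at least 5.6-fold higher number from compound 1 to compound 3 (0.75 log units; beyond the scatter) and an at least 3.8-fold higher number from compound 2 to compound 3 (0.58 log units; beyond the scatter) are the two beyond the scatter, and both concern a change from an aryl group to cyclohexyl.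

Compound 4 `CC(C)(C)c1ccc(NC(=O)Nc2cccc(CNc3nccnc3Cl)c2)cc1` keeps the aryl group and changes only its substituent: tert-butyl in place of ethoxy on an aromatic carbon. The step that bears most directly on this is the swap of one substituted aryl for another, which in this assay was within the scatter. The steps to compound 3 involve loss of the aryl ring and so do not apply here. No step beyond the scatter is therefore expected in this assay, as a 1.0-fold lower number from compound 1 to compound 4 (0.00 log units; within the scatter) indicates. Compound 4 is expected to give about 7000 nM, somewhere between 3000 nM and 18000 nM.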

Compound 4, half-maximal inhibitory concentration: 7550 nM
Estimate against measurement, compound 4: 1.1-fold (0.03 log units) below; the measured number falls inside the stated range.
By their numbers in this assay, from the lowest: compounds 1, 4 and 2 (each within the scatter of the next). At a limit, above all of these: compound 3.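

With tert-butyl in place of ethoxy, this assay shows a 1.1-fold higher number from compound 1 to compound 4 (0.03 log units; within the scatter) and so does not separate the two groups. Ethoxy brings an oxygen and a hydrogen-bond acceptor, while tert-butyl brings only carbon and no acceptor, so on this aromatic carbon, para to a large group, the oxygen is not needed to keep the number in the same range; the earlier swap to 2-fluorophenyl changed more than this one substituent and could not show that. Nothing measured here accounts for why the two groups read alike.

Going by these compounds, both groups carry no net charge and no ring, so it stays open whether an amine or a carboxylic acid on this carbon would read the same. The same holds for a longer chain or a second ring at this place.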